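The source may hold more compounds than are shown below. What is called first, only, known or untested is meant among the compounds shown, and "the series" means these compounds.

Compound 1 `COCc1ncc2cnnc(S)n12` is the reference point of this comparison. In a functional assay for inhibition, with Homo sapiens as the target (a lower number here means a stronger inhibitor, a higher number a weaker inhibitor), compound 1 gives no number but only a limit of the assay, > 48000 nM. Two close relatives of compound 1 have been measured. Compound 2 `Cc1ncc2cnnc(S)n12` differs from compound 1 by hydrogen in place of methoxy on a saturated chain carbon bound to an aromatic carbon; in this assay compound 2 also returns a limit, > 48000 nM. Compound 3 `COCc1nc(C)c2cnnc(S)n12` carries methyl in place of hydrogen on an aromatic carbon; for compound 3 this assay again gives a limit, > 48000 nM. Neither step can be sized: a step that the two limits leave unreadable from compound 1 to compound 2 and a step that the two limits leave unreadable from compound 1 to compound 3, because of the limit of > 48000 nM in this assay, at which 3 of the 3 values shown sit.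

Compound 4 `C=CCSc1nncc2cnc(COC)n12` arises from compound 1 by the change (allyl in place of hydrogen on a sulfur). Among the measured compounds shown here, neither measured step touches the sulfur, and both are unreadable in size, so nothing among the measured compounds speaks for a direction of this change. The step from compound 1 to compound 4 is therefore expected to be an at least 1.2-fold lower number from compound 1 to compound 4 (0.07 log units; that floor lies within the scatter), with wide uncertainty. Compound 4 is estimated to give about 40000 nM in this assay, within a range from 8000 nM to 200000 nM, and a limit rather than a number is the most likely outcome.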

Compound 4, half-maximal inhibitory concentration: 79000 nM
Estimate against measurement, compound 4: 2.0-fold (0.30 log units) below, within the range that was stated.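

Compound 4 gives a real number, but compound 1 gives only a limit, so the step between compound 1 and compound 4 cannot be sized: the limit of > 48000 nM in this assay, at which 3 of the 4 values shown sit. The compounds shown leave open whether allyl in place of hydrogen on the sulfur makes a stronger or a weaker inhibitor in this assay, and by how much.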